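Aryl variation on the carbonyl carbon, compound 3 pending

The source may hold more compounds than are shown below. What is called first, only, known or untested is meant among the compounds shown, and "the series" means these compounds.

Compound 1 `COc1cc(-c2cc(/C=C/C(=O)c3ccc(N)cc3)[nH]n2)cc(OC)c1OC` and compound 2 `COc1cc(-c2cc(/C=C/C(=O)c3ccc(Cl)c(Cl)c3)[nH]n2)cc(OC)c1OC` differ only in the aryl group on the carbonyl carbon. In a functional assay on CCRF-CEM cells (Homo sapiens) for cytotoxicity, read by sulforhodamine B assay, with a stated time of 48 h, tested at 0.01 uM (on this read-out lower numbers stand for a stronger effect and higher numbers for a weaker effect at the one concentration tested), compound 1 gives 96% and compound 2 gives 98%; the step of a number 2 percentage points higher from compound 1 to compound 2 (within the scatter) lies within the scatter, so compound 2 stands at one of two numbers that cannot be told apart. Compound 3 `COc1ccc(C(=O)/C=C/c2cc(-c3cc(OC)c(OC)c(OC)c3)n[nH]2)cc1OC` carries 3,4-dimethoxyphenyl in place of 3,4-dichlorophenyl on a carbonyl carbon. Within the data shown here, the one step bearing on this exchange, a number 2 percentage points higher from compound 1 to compound 2 (within the scatter), showed nothing beyond the scatter. For compound 3 no step beyond the scatter is therefore expected, a number 1 percentage points lower from compound 2 to compound 3 (within the scatter). Compound 3 is estimated at 97%, between 85% and 106%.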

Compound 3, a percentage reported as activity, at one concentration (the size of the read-out at that concentration, not a potency): 95%
The estimate for compound 3 lay 2 percentage points above the measured number, and the stated range covers the measured number.
By their numbers in this assay, from the lowest: compounds 3, 1 and 2 (each within the scatter of the next).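

In this assay the entry of 3,4-dimethoxyphenyl on a carbonyl carbon gives a number 3 percentage points lower from compound 2 to compound 3 (within the scatter) and, set against 4-aminophenyl, a number 1 percentage points lower from compound 1 to compound 3 (within the scatter) at this position. The hydrogen-bond acceptors that enter with 3,4-dimethoxyphenyl thus leave the number within the scatter, and the three aryl groups cannot be told apart at this one concentration. No evidence at hand accounts for this result.

Open, from the compounds shown here alone, is whether a carboxylic acid, a morpholine or a longer chain on the carbonyl carbon would move the number beyond the scatter. Also open, going by these compounds, is whether compounds 1, 2 and 3 separate at a higher concentration.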